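Aryl exchange on the amine of compound 1

The compounds below may be only part of what the source reports. "The series", "measured", "known", "first", "only" and "open" are said of these compounds alone.

Compound 1 `Cc1ccc(Nc2cc(NC(=O)Nc3c(Cl)cccc3Cl)ncn2)cc1C` gives 47.5% in a functional assay on NCI-H520 cells (Homo sapiens) for inhibition, read by MTT assay, with a stated time of 48 h, tested at 10 uM (a higher number here means more inhibition at the concentration tested (going by the name of the read-out), a lower number less inhibition), the second highest of the three numbers measured. Compound 3 `COc1cc(NC(=O)Nc2cc(Nc3cc(Br)ccc3OC)ncn2)cc(OC)c1` is the nearest with 43.5%, and compound 2 `COc1cc(NC(=O)Nc2cc(Nc3cc(I)ccc3OC)ncn2)cc(OC)c1` gives 55%; both differences to compound 1 lie within the scatter. Within the data shown here, the only measured step, a number 11.5 percentage points lower from compound 2 to compound 3 (beyond the scatter), concerns an exchange on a different part of the structure and does not bear on the change considered here. Compound 4 `CCc1ccc(Nc2cc(NC(=O)Nc3c(Cl)cccc3Cl)ncn2)cc1` differs from compound 1 by 4-ethylphenyl in place of 3,4-dimethylphenyl on a nitrogen on an aromatic ring. Among the measured compounds shown here, no measured step covers this exchange, so nothing beyond the scatter is expected. The estimate for compound 4 in this assay is 46%, with a range of 28% to 64%. The expected step is a number 1.5 percentage points lower from compound 1 to compound 4 (within the scatter).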

Compound 4, a percentage reported as inhibition, at one concentration (the size of the read-out at that concentration, not a potency): 31.5%
Estimate against measurement, compound 4: 14.5 percentage points above; the range from low to high includes it.
By their numbers in this assay, from the lowest: compound 4; then compounds 3, 1 and 2 (each within the scatter of the next, the first and the last beyond it).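

Among these compounds, the exchange at this nitrogen is the first step read at this position: with the same atoms, joined differently, in this assay the aryl group gives a number 16 percentage points lower from compound 1 to compound 4 (beyond the scatter), so the placement of carbon on this ring alone can move the number beyond the scatter. No measurement at hand accounts for this step.

Open, from the compounds shown here alone, is whether 4-methylphenyl or 4-propylphenyl on this nitrogen would read closer to compound 1 or to compound 4. Also open, going by these compounds, is whether the step holds when the rest of the core of compound 1 changes.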